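The source may report more compounds than this note shows. Statements on the series, on what has been measured and on what is new or still open speak of the compounds shown alone.

Measured so far in an assay on isolated protein for inhibition of DNA topoisomerase 1 (Homo sapiens), tested at 100 uM; on this read-out lower numbers stand for a weaker effect and higher numbers for a stronger effect at the one concentration tested:
- compound 1 `Clc1ccc(-c2cc(-c3ccoc3)cc(-c3cccs3)n2)cc1` gives 0%
- compound 2 `Clc1ccc(-c2cc(-c3ccoc3)cc(-c3ccsc3)n2)cc1` gives 0%

Compound 1 stands level with compound 2 at the digits shown; in this assay the one measured step, no change at the digits printed from compound 1 to compound 2 (within the scatter), lies within the scatter. Neither compound shows any inhibition at the concentration tested.

Compound 3 `Clc1ccc(-c2cc(-c3ccco3)cc(-c3cccs3)n2)cc1` has not yet been measured. It differs from compound 1 in one place: furan-2-yl in place of furan-3-yl on an aromatic carbon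

For the measured compounds named here, the only step that bears on this change is no change at the digits printed from compound 1 to compound 2 (within the scatter), which moved one five-membered ring with one hetero atom from one attachment point to another and produced nothing beyond the scatter. The change from compound 1 to compound 3 is of the same kind, on the other five-membered ring. Going by the values given here, no step of any size is therefore expected in this assay. For compound 3 the estimated value is 0%, with a range from 0% to 12%; the expected step is no change at the digits printed from compound 1 to compound 3 (within the scatter), that is, nothing beyond the scatter.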

Compound 3, a percentage reported as inhibition, at one concentration (the size of the read-out at that concentration, not a potency): 2.7%
Compound 3: middle estimate off by 2.7 percentage points, on the low side; low and high end bracket the measured number.
By their numbers in this assay, from the lowest: compounds 1, 2 and 3 (each within the scatter of the next).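

In this assay, furan-2-yl in place of furan-3-yl opposite the ring nitrogen gives a number 2.7 percentage points higher from compound 1 to compound 3 (within the scatter) with the 4-chlorophenyl and thiophen-2-yl groups unchanged. The attachment point of the furan ring can therefore be moved at this position without a step beyond the scatter, a result that the earlier pair, which differed only in the thiophene attachment, could not show. No measured evidence bears on this result.

Still open, as far as these compounds go, is whether any group at this position other than a furan ring, such as an amine or a carboxylic acid, would give a step beyond the scatter. Also open, from the compounds shown here alone, is whether a hydroxyl group in place of the chlorine of the 4-chlorophenyl group would change the read-out.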